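The compounds below may be only part of what the source reports. "The series", "measured", "known", "first", "only" and "open" are said of these compounds alone.

Values measured in a functional assay on HT-29 cells (Homo sapiens) for antiproliferative activity, read by MTT assay, with a stated time of 72 h; a lower number here means a stronger inhibitor, a higher number a weaker inhibitor:
- Compound 1 `C=CC(=O)N(CC(=O)OCC)c1nc(-c2ccccc2)cs1`: 19000 nM
- Compound 2 `C=CC(=O)N(CC(=O)OC)c1nc(-c2ccccc2)cs1`: > 30000 nM

Compound 2 stands at the limit of > 30000 nM in this assay, at which 1 of the 2 values shown sits, so its value is a limit and not a number. Compound 3 `C=CC(=O)N(CC(=O)OC(C)(C)C)c1nc(-c2ccccc2)cs1` changes the ester of compound 2: tert-butyl in place of methyl on an oxygen next to a carbonyl group, methoxycarbonyl to tert-butoxycarbonyl. Among the compounds with values here, only one measured step bears on this place, an at least 1.5-fold higher number from compound 1 to compound 2 (0.19 log units; that floor lies within the scatter), so it sets no firm size or direction. Compound 1 does give a number, 19000 nM, so a modest shift towards a lower number is expected in this assay. The expected change is an at least 1.5-fold lower number from compound 2 to compound 3 (0.17 log units; that floor lies within the scatter). For compound 3 the estimate is 20000 nM, with an expected range of 8000 nM to 45000 nM.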

Compound 3, half-maximal inhibitory concentration: > 30000 nM
Compound 3 gave a limit, no number; the forecaster's own chance of this, stated with the estimate: 45%; middle value at least 1.5-fold (0.17 log units) away from the limit.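

In this assay, the step from methoxycarbonyl to tert-butoxycarbonyl cannot be read: compound 2 and compound 3 both give only limits. Set against the ethyl ester, the change reads as an at least 1.5-fold higher number from compound 1 to compound 3 (0.19 log units; that floor lies within the scatter), so tert-butyl brings no sign of a lower number at this oxygen. Of the three esters, only compound 1 gives a number, and the limit now holds most of the series: the limit of > 30000 nM in this assay, at which 2 of the 3 values shown sit.

The compounds shown leave open how a longer chain such as n-butyl, or a carboxylic acid in place of the ester, would read in this assay. They also leave open whether ethyl is truly preferred at this oxygen.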